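The compounds below may be only part of what the source reports. "The series", "measured", "known", "first", "only" and "open" are said of these compounds alone.

Going by the values given here, compound 2 `COC(=O)[C@@H](C)NC(=O)Cn1cc(C2=C(c3c[nH]c4ccccc34)C(=O)N(C)C2=O)c2ccccc21` gives 9340 nM in a functional assay on Bel-7402 cells (Homo sapiens) for cytotoxicity, read by MTT assay, with a stated time of 24 h (on this read-out higher numbers stand for weaker inhibition and lower numbers for stronger inhibition), the lowest of the two numbers known; compound 1 `COC(=O)[C@@H](CC(C)C)NC(=O)Cn1cc(C2=C(c3c[nH]c4ccccc34)C(=O)N(C)C2=O)c2ccccc21` gives 42400 nM in this assay. Among the compounds with values here, the single measured step, a 4.5-fold lower number from compound 1 to compound 2 (0.66 log units; beyond the scatter), is the only guide, and it concerns a different group at the same carbon. Compound 3 `COC(=O)C[C@@H](NC(=O)Cn1cc(C2=C(c3c[nH]c4ccccc34)C(=O)N(C)C2=O)c2ccccc21)C(=O)OC` differs from compound 2 by methoxycarbonyl in place of hydrogen on a saturated chain carbon, two bonds along the chain from an amide-type nitrogen and a carbonyl carbon. Because enlarging that carbon went with a 4.5-fold lower number from compound 1 to compound 2 (0.66 log units; beyond the scatter) in reverse, a modestly higher number is expected, though the entering group is unlike isopropyl. Compound 3 is estimated at 18000 nM, a step of a 1.9-fold higher number from compound 2 to compound 3 (0.28 log units; within the scatter), with a range from 6000 nM to 55000 nM.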

Compound 3, half-maximal inhibitory concentration: 9360 nM
For compound 3 the middle estimate is 1.9-fold (0.28 log units) above the measured one; low and high end bracket the measured number.
By their numbers in this assay, from the lowest: compounds 2 and 3 (each within the scatter of the next); then compound 1.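

In this assay the change to methoxycarbonyl in place of hydrogen on this saturated chain carbon is a 1.0-fold higher number from compound 2 to compound 3 (0.00 log units; within the scatter) and so a larger group here does not by itself go with a higher number. Methoxycarbonyl in place of isopropyl at the same carbon gives a 4.5-fold lower number from compound 1 to compound 3 (0.66 log units; beyond the scatter) and thus, of the three compounds, only compound 1 stands apart. No evidence at hand bears on the reason for this result. As far as these compounds go, whether a carboxylic acid or an amine at this carbon fits with compound 2 and compound 3 or with compound 1 remains open, as does the effect of a longer chain ending in methoxycarbonyl.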